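The compounds below may be only part of what the source reports. "The series", "measured", "known", "first", "only" and "open" are said of these compounds alone.

Measured compounds so far:
- compound 1, `c1ccc(-c2cn3ccnc3c(-c3ccc4ncn(C5CCCCC5)c4c3)n2)cc1`, gives 33.3% in a functional assay on A549 cells (Homo sapiens) for inhibition, read by sulforhodamine B assay, with a stated time of 48 h, tested at 10 uM; a higher number here means more inhibition at the concentration tested (going by the name of the read-out), a lower number less inhibition
- compound 2, `COc1ccc(-c2cn3ccnc3c(-c3ccc4ncn(C5CCCCC5)c4c3)n2)cc1`, gives 68.6% in this assay
- compound 3, `Fc1ccc(-c2cn3ccnc3c(-c3ccc4ncn(C5CCCCC5)c4c3)n2)cc1`, gives 12.8% in this assay

Compound 2 stands highest of the three numbers in this assay. Its nearest neighbour is compound 1, and the step of a number 35.3 percentage points higher from compound 1 to compound 2 (beyond the scatter) lies beyond the scatter; the furthest is compound 3, and the step of a number 55.8 percentage points lower from compound 2 to compound 3 (beyond the scatter) also lies beyond the scatter.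

The next compound, compound 4, `Brc1ccc(-c2cn3ccnc3c(-c3ccc4ncn(C5CCCCC5)c4c3)n2)cc1`, differs from compound 2 in one place: bromo in place of methoxy on an aromatic carbon. For the measured compounds named here, the steps that bear on it are those that touch the same position of the shared core. Going from compound 1 to compound 2 a methoxy entered and the number rose, a number 35.3 percentage points higher from compound 1 to compound 2 (beyond the scatter); going from compound 2 to compound 3 the methoxy left for a fluoro and the number fell by a large amount, a number 55.8 percentage points lower from compound 2 to compound 3 (beyond the scatter); and a number 20.5 percentage points lower from compound 1 to compound 3 (beyond the scatter) shows a fluoro alone lowering the number by a modest amount. Since a bromo, like a fluoro, brings no hydrogen-bond acceptor where the methoxy had one, a fall in this assay beyond the scatter is expected, estimated as a number 43.6 percentage points lower from compound 2 to compound 4 (beyond the scatter). Compound 4 is therefore expected to give about 25% in this assay, within a range from 5% to 55%.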

Compound 4, a percentage reported as inhibition, at one concentration (the size of the read-out at that concentration, not a potency): 15.3%
Beside the measured number, compound 4's estimate is 9.7 percentage points above it; measured number inside the range.
By their numbers in this assay, from the lowest: compounds 3 and 4 (each within the scatter of the next); then compound 1; then compound 2.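

In this assay, bromo in place of methoxy, on the aromatic carbon para to a large group, costs most of the number (a number 53.3 percentage points lower from compound 2 to compound 4 (beyond the scatter)), so a second halogen also fails to keep what the methoxy of compound 2 gave. The two halogens cannot be told apart at this position (a number 2.5 percentage points higher from compound 3 to compound 4 (within the scatter)), and the swap of fluoro for bromo therefore makes no difference that this read-out can show. Bromo also lowers the number against the unsubstituted compound (a number 18 percentage points lower from compound 1 to compound 4 (beyond the scatter)), which shows that among these four compounds both halogens lie under hydrogen and only the methoxy lies over it.

The compounds shown leave open whether the rise belongs to the methoxy alone or would also come with a hydroxyl, an ethoxy or a dimethylamino group at this position. No measurement given here accounts for the methoxy standing apart from hydrogen, fluoro and bromo.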